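A new ring substituent on the shared core

A few compounds are considered here, and "the series" means these few. Any claim that something is new, unique, unknown or untested is made for them only; others in the source may bear on it.

Measured so far:
- Compound 1, `O=C(CSc1nnc(-c2ccncc2)o1)N/N=C/c1ccc(Br)cc1`, gives 21300 nM in a functional assay on SW 1116 cells (Homo sapiens) for cytotoxicity, read by MTT assay, with a stated time of 48 h; on this read-out lower numbers stand for stronger inhibition and higher numbers for weaker inhibition.
- Compound 2, `COc1cccc(/C=N/NC(=O)CSc2nnc(-c3ccncc3)o2)c1`, gives 16500 nM in this assay.

Among these two numbers compound 1 stands highest, that is, its inhibition is the weaker one on this read-out. For the measured compounds named here, its nearest neighbour is compound 2, and the only measured step, a 1.3-fold lower number from compound 1 to compound 2 (0.11 log units; within the scatter), falls within the usual scatter of repeated measurements, so the two compounds cannot be ranked against each other with confidence.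

The next compound to be measured is compound 3, `O=C(CSc1nnc(-c2ccncc2)o1)N/N=C/c1cc(Cl)cc(Cl)c1O`. It differs from compound 1 in one place: 3,5-dichloro-2-hydroxyphenyl in place of 4-bromophenyl on a carbon with a double bond to nitrogen.

Going by the values given here, only one measured step bears on this change, a 1.3-fold lower number from compound 1 to compound 2 (0.11 log units; within the scatter), and it exchanged the ring on the same carbon without moving the number beyond the scatter. The group that enters compound 3 has not been measured on this core, so nothing in the data points to a particular direction. The expectation for compound 3 is therefore a step of a 1.3-fold lower number from compound 1 to compound 3 (0.12 log units; within the scatter), within the scatter. The estimate for compound 3 in this assay is 16000 nM, with a range from 5000 nM to 50000 nM.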

Compound 3, half-maximal inhibitory concentration: 5030 nM
Beside the measured number, compound 3's estimate is 3.2-fold (0.50 log units) above it; the measured number falls inside the stated range.
By their numbers in this assay, from the lowest: compound 3; then compounds 2 and 1 (each within the scatter of the next).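

The ring on the carbon with a double bond to nitrogen can move the number beyond the scatter, which the earlier pair of compounds did not show. In this assay, 3,5-dichloro-2-hydroxyphenyl in place of 4-bromophenyl gives a 4.2-fold lower number from compound 1 to compound 3 (0.63 log units; beyond the scatter), and in place of 3-methoxyphenyl it gives a 3.3-fold lower number from compound 2 to compound 3 (0.52 log units; beyond the scatter), so compound 3 shows the strongest inhibition of the three. The entering group carries one hydrogen-bond donor and one acceptor where 4-bromophenyl has none, yet nothing measured here explains the gain in inhibition.

The compounds shown leave open whether the lower number goes with the hydroxyl group, with the two chlorine atoms or only with all of them together, and a 2-hydroxyphenyl or a 3,5-dichlorophenyl group on the same carbon would help to separate these possibilities. Also open, on these data alone, is how the number would respond to a quite different substituent on this ring, such as an amine or a carboxylic acid.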